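Swapping a bromophenoxy tail for a phenylsulfonyl tail

The source may report more compounds than this note shows. Statements on the series, on what has been measured and on what is new or still open speak of the compounds shown alone.

The series comprises compound 1 `COc1cc(C(C)=O)ccc1OCCCN1CCC(C(c2ccc(F)c(F)c2)c2ccc(F)c(F)c2)CC1`, compound 2 `COc1cc(C(C)=O)ccc1OCCCCCN1CCC(C(c2ccc(F)cc2)c2ccc(F)cc2)CC1` and compound 3 `Fc1ccc(C(c2ccc(F)cc2)C2CCN(CCCOc3ccc(Br)cc3)CC2)cc1`, all examined in a functional assay (aorta) with Oryctolagus cuniculus as the target; on this read-out higher numbers stand for weaker binding and lower numbers for tighter binding. In this assay compound 1 gives 2.51 nM, compound 2 gives 3.16 nM and compound 3 gives 1.59 nM. Compound 3 carries the lowest of the three numbers, yet its gap to compound 1 and its gap to compound 2 both lie within the usual scatter, so no order among the three can be read from these values. Compound 4 `O=S(=O)(CCCN1CCC(C(c2ccc(F)cc2)c2ccc(F)cc2)CC1)c1ccccc1` has not yet been measured. It differs from compound 3 in one place: phenylsulfonyl in place of 4-bromophenoxy on a saturated chain carbon, three bonds along the chain from an amine nitrogen in a ring. Among the compounds with values here, no pair of measured compounds shows this change, so the data give no direct guide to its size. The three measured values all sit in a narrow band despite their varied chains and aromatic groups, and the number for compound 4 is expected to remain in the same region. Compound 4 is therefore expected to give about 4 nM, with a range from 1.3 nM to 12 nM. This estimate means a step of a 2.5-fold higher number from compound 3 to compound 4 (0.40 log units; beyond the scatter), a small move toward weaker binding that is expected to stay close to the scatter.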

Compound 4, dissociation constant: 20 nM
For compound 4 the middle estimate is 5.0-fold (0.70 log units) below the measured one; measured number outside the range, above it.
By their numbers in this assay, from the lowest: compounds 3, 1 and 2 (each within the scatter of the next); then compound 4.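

In this assay, replacing 4-bromophenoxy with phenylsulfonyl gives a 13-fold higher number from compound 3 to compound 4 (1.10 log units; beyond the scatter), the first difference in this series to stand beyond the usual scatter. The earlier values lay within the scatter of one another, although those compounds differ in several places at once, and so they gave no sign of how the read-out responds to a single change of tail; this pair shows that the group on a saturated chain carbon, three bonds along the chain from an amine nitrogen in a ring, can move the number substantially, here toward weaker binding. No supporting data are available to explain the size or direction of this step.

The single step changes two things together, removing the bromine and replacing the ether oxygen with a sulfonyl, so the compounds shown cannot tell which of these goes with the weaker binding. A plain phenoxy tail and a 4-bromophenylsulfonyl tail on the same chain would separate the two, and a sulfonamide tail would show whether the step extends to other sulfur-linked groups.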